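A few compounds are considered here, and "the series" means these few. Any claim that something is new, unique, unknown or untested is made for them only; others in the source may bear on it.

In a functional assay on CRL2813 cells (Homo sapiens) for cytotoxicity, read by sulforhodamine B assay, with a stated time of 5 days (a higher number here means a weaker inhibitor, a lower number a stronger inhibitor), three compounds built on one shared core have been measured. Compound 1 `O=C(Nc1cccc(C(=O)O)c1)N[C@H]1CC[C@H](Oc2ccc(F)cc2)CC1` reaches only the limit of this assay, > 20000 nM. Compound 2 `O=C(Nc1ccccc1Br)N[C@H]1CC[C@H](Oc2ccc(F)cc2)CC1` gives 7700 nM, and compound 3 `O=C(Nc1cccc(I)c1)N[C@H]1CC[C@H](Oc2ccc(F)cc2)CC1` gives 5200 nM. Among the two plain numbers, compound 2 stands highest; the nearest number is a 1.5-fold lower number from compound 2 to compound 3 (0.17 log units; within the scatter), a step within the scatter, so these two cannot be ordered. The steps away from compound 1 are larger, an at least 2.5-fold lower number from compound 1 to compound 2 (0.41 log units; beyond the scatter) and an at least 3.8-fold lower number from compound 1 to compound 3 (0.58 log units; beyond the scatter), and both are counted from the limit (the limit of > 20000 nM in this assay, at which 1 of the 3 values shown sits).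

Compound 4 `O=C(Nc1ccccc1OC(F)(F)F)N[C@H]1CC[C@H](Oc2ccc(F)cc2)CC1` has not yet been measured. It differs from compound 2 in a single place: trifluoromethoxy in place of bromo on an aromatic carbon. Going by the values given here, no measured step exchanges bromo for trifluoromethoxy. The closest comparison, 3-iodophenyl in place of 2-bromophenyl, stayed within the scatter, while the larger steps from compound 1 turned on removing carboxy, which compound 4 does not touch. A change no larger than the scatter is therefore expected in this assay, in either direction. Compound 4 is expected at 7000 nM, between 3000 nM and 16000 nM. The step this implies, a 1.1-fold lower number from compound 2 to compound 4 (0.04 log units; within the scatter), is expected to remain within the scatter.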

Compound 4, half-maximal inhibitory concentration: > 20000 nM
Compound 4 gave a limit, no number; the forecaster's own chance of this, stated with the estimate: 10%; middle value at least 2.8-fold (0.45 log units) away from the limit.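

In this assay, the group on an aromatic carbon ortho to a large group matters: trifluoromethoxy in place of bromo gives an at least 2.5-fold higher number from compound 2 to compound 4 (0.41 log units; beyond the scatter). This change touches no carboxy group, yet it moves the result beyond the scatter, unlike the exchange of the two halogen-bearing aromatic groups, which gave a 1.5-fold lower number from compound 2 to compound 3 (0.17 log units; within the scatter). So loss of activity in this series is not confined to the carboxy compound, and compound 4 joins compound 1 at the limit of the assay, for compound 4 gives > 20000 nM, which is a limit and not a number: the limit of > 20000 nM in this assay, at which 2 of the 4 values shown sit.

As far as these compounds go, how large the step really is stays open, and a single exchange at this place cannot separate the features of trifluoromethoxy that might matter from one another. Also open, from the compounds shown here alone, is whether a methyl group, a chlorine atom or an amine on the same aromatic carbon would keep the result near that of compound 2 or take it to the limit reached by compound 4.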